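The source may hold more compounds than are shown below. What is called first, only, known or untested is meant among the compounds shown, and "the series" means these compounds.

Series notes. Compound 1 `CC1(C)C=C(n2ccccc2=O)c2cc(S(N)(=O)=O)ccc2O1` carries the sulfamoyl group on the shared core. Within the data shown here, in a functional assay on the whole organism (trachea) with Rattus norvegicus as the target (on this read-out higher numbers stand for larger maximal responses and lower numbers for smaller maximal responses), compound 1 gives 92.1%, the only number held for it; one further entry for compound 1 gives no single value. Compound 2 `CC1(C)C=C(n2ccccc2=O)c2cc(S(=O)(=O)Nc3ccccc3)ccc2O1` is a related member of the series; in this assay compound 2 gives 7.85%; 88% (2 entries), and the spread of its entries the several entries of compound 2 in this assay, 7.85%; 88% (2 entries) shows how far repeated readings of this kind can lie apart, so single values are read with caution. Among the measured compounds shown here, no step between measured compounds bears on the change under study. Compound 3 `CN(C)S(=O)(=O)c1ccc2c(c1)C(n1ccccc1=O)=CC(C)(C)O2` has not yet been measured; it differs from compound 1 in one place: dimethylamino in place of amino on a sulfonyl sulfur. Compound 1 sits near the top of the read-out, so the change is expected to give, if anything, a small downward step in this assay, not clearly beyond the usual scatter, with a wide range allowed for the variability seen in this series. The estimate for compound 3 is 80%, between 40% and 98%. This expected value means a step of a number 12.1 percentage points lower from compound 1 to compound 3 (beyond the scatter).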

Compound 3, largest response reached (Emax), in percent of the reference or control that the assay uses: 74.1%
Beside the measured number, compound 3's estimate is 5.9 percentage points above it; the range from low to high includes it.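

In this assay, among these compounds, the change from sulfamoyl to dimethylsulfamoyl gives a number 18 percentage points lower from compound 1 to compound 3 (beyond the scatter), the first step that can be read at this position on the sulfonyl sulfur. Compound 3 has no hydrogen-bond donor on this group, yet its response remains well above the low entry of compound 2, so a sizeable maximal response does not require the donor counted on the amino group. The step is modest and compound 1 holds only one number, while repeated readings in this series can lie far apart: the several entries of compound 2 in this assay, 7.85%; 88% (2 entries)

The compounds shown do not separate the loss of the donor from the gain of the added carbon atoms; a methylamino group on the sulfonyl sulfur, or a cyclic amine such as pyrrolidine in the same place, would bear on that. The phenylamino group of compound 2 also stays unplaced against amino and dimethylamino, as the entries of compound 2 disagree too widely for any step to be read.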